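Changing trifluoromethyl to methyl on an inactive oxadiazole acid

The compounds below may be only part of what the source reports. "The series", "measured", "known", "first", "only" and "open" are said of these compounds alone.

Compound 1 `Cc1cc(CCC(=O)O)ccc1-c1noc(-c2ccc(OC(C)C)c(C(F)(F)F)c2)n1` is measured in a functional assay on CHO cells with sphingosine 1-phosphate receptor 4 (Homo sapiens) as the target, read by GTPgammaS binding (on this read-out lower numbers stand for an effect already at smaller amounts and higher numbers for an effect only at larger amounts of compound), where compound 1 gives > 10000 nM, which is a limit of the assay and not a number. Compound 2 `CCOc1ccc(-c2nc(-c3ccc(CCC(=O)O)cc3C)no2)cc1C(F)(F)F`, with hydrogen in place of methyl on the saturated chain carbon bound to the ring oxygen, gives in this assay > 10000 nM, again a limit. Compound 3 `COc1ccc(-c2nc(-c3ccc(CCC(=O)O)cc3C)no2)cc1C(F)(F)F`, carrying methoxy instead of isopropoxy, gives > 10000 nM, also a limit. The steps between them are therefore a step that the two limits leave unreadable from compound 1 to compound 2, a step that the two limits leave unreadable from compound 1 to compound 3 and a step that the two limits leave unreadable from compound 2 to compound 3, all unreadable, as summarised by the limit of > 10000 nM in this assay, at which 3 of the 3 values shown sit.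

Compound 4 `Cc1cc(-c2nc(-c3ccc(CCC(=O)O)cc3C)no2)ccc1OC(C)C` differs from compound 1 by methyl in place of trifluoromethyl on an aromatic carbon. Among the compounds with values here, none of the measured steps touches the trifluoromethyl group, so they give no guide to the size or direction of this change; they only show that every measured member of the series sits at the limit. Compound 4 is therefore expected to give about 15000 nM, within a range from 3000 nM to 60000 nM, most likely again reported as a limit. The step that the limit leaves unreadable from compound 1 to compound 4 is the expected outcome, with no shift beyond the scatter anticipated.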

Compound 4, half-maximal effective concentration: > 10000 nM
Compound 4 ended at the assay's limit; the forecaster's own chance of this, stated with the estimate: 75%; the middle value does not contradict the limit.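

No new step can be read: compound 1 and compound 4 both stop at a limit of the assay, so the swap of trifluoromethyl for methyl has no measurable size. All the values shown are such limits: the limit of > 10000 nM in this assay, at which 4 of the 4 values shown sit.

The compounds shown leave open whether either group makes any difference to the effect in this assay.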